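Shared-core series: carbamoyl in place of a larger side group

The source may report more compounds than this note shows. Statements on the series, on what has been measured and on what is new or still open speak of the compounds shown alone.

Measured compounds:
compound 1 `N=C(N)NCCC[C@H](NC(=O)CN(c1ncnc2c1ncn2C1CCCCO1)C1CC1)C(=O)OCc1ccccc1` — 52.4%
compound 2 `N=C(N)NCCC[C@H](NC(=O)CN(c1nc(Cl)nc2[nH]cnc12)C1CC1)C(=O)OCc1ccccc1` — 30.6%
compound 3 `C[C@@H](O)[C@H](NC(=O)CN(c1nc(Cl)nc2[nH]cnc12)C1CC1)C(=O)O` — 30.1%

All three were run in a functional assay on the whole organism (Tail, strain ICR) with Mus musculus as the target, in the tail flick test, with a stated time of 60 min, at a dose of 25 umol/kg by the oral route; on this read-out higher numbers stand for a stronger effect at the one dose given and lower numbers for a weaker effect. Compound 1 gives 52.4%, the highest of the three numbers. Compound 2 gives 30.6% and compound 3 gives 30.1%; each of these lies beyond the scatter below compound 1, while compound 2 and compound 3 fall within the scatter of each other and are not ordered. For the measured compounds named here, no two measured compounds differ in one place only, so no single step can be read off from the measured set, and the three values stand as they are.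

Compound 4 `NC(=O)CC[C@H](NC(=O)CN(c1ncnc2c1ncn2C1CCCCO1)C1CC1)C(=O)OCc1ccccc1` has not yet been measured in this assay. It differs from compound 1 in one place:
a group of 3 heavy atoms (1 carbon, 1 nitrogen, 1 oxygen; no ring) in place of a group of 5 heavy atoms (2 carbon, 3 nitrogen; no ring), on a saturated chain carbon, three bonds along the chain from an amide-type nitrogen and a carbonyl carbon

The measured set holds no change of this kind, so its size cannot be taken from a known step. Since compound 1 gives 52.4% and the other two compounds sit well below it, a downward step beyond the scatter is expected, a number 17.4 percentage points lower from compound 1 to compound 4 (beyond the scatter). For compound 4 the estimated value in this assay is 35%, with a range from 15% to 55%; this estimate is uncertain.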

Compound 4, a percentage reported as activity, at one dose (the size of the read-out at that dose, not a potency): 39.4%
Compound 4: the middle estimate sits 4.4 percentage points below what was measured, and the stated range covers the measured number.
By their numbers in this assay, from the lowest: compounds 3, 2 and 4 (each within the scatter of the next); then compound 1.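

In this assay, for the compounds shown here, carbamoyl in place of the group of 5 heavy atoms, on a saturated chain carbon, three bonds along the chain from an amide-type nitrogen and a carbonyl carbon, gives a number 13 percentage points lower from compound 1 to compound 4 (beyond the scatter), the first single change that can be read. The step shows that this position bears on the read-out, while compound 4 still gives 39.4%, so the effect at this one dose does not depend entirely on the larger group found in compound 1. Nothing measured in this set accounts for the size of the step, and no mechanistic reading can be attached to it.

As far as these compounds go, how an amine or a carboxylic acid at the same place, or a longer chain ending in carbamoyl, would stand against compound 1 and compound 4 remains open. Also open, from the compounds shown here alone, are whether the same change gives a step of similar size on the core of compound 2, and whether the step reflects a shift in potency, since the read-out comes from a single dose and time.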